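Replacing the methoxy anilide with a methyl anilide

This account rests on a few compounds, and the source may have more. Where it says the series, first, only, none or still open, it means among the compounds named here.

Compound 3 `COc1ccc(NC(=O)/C=C/c2coc3cc(OC)ccc3c2=O)cc1` carries a 4-methoxyphenyl on the amide nitrogen of the shared core. In a functional assay on Huh-7 cells (Homo sapiens) for inhibition, read by MTT assay, with a stated time of 48 h (a lower number here means a stronger inhibitor, a higher number a weaker inhibitor), compound 3 gives > 100000 nM, which is a limit of the assay rather than a number. It sits at the limit of > 100000 nM in this assay, at which 1 of the 3 values shown sits, the weakest position among the three measured compounds. Compound 2 `COc1ccc2c(=O)c(/C=C/C(=O)Nc3ccccc3)coc2c1` gives 9050 nM in this assay, and compound 1 `COc1ccc2c(=O)c(/C=C/C(=O)Nc3cccc(C)c3)coc2c1` gives 15500 nM. Both steps, an at least 11-fold higher number from compound 2 to compound 3 (1.04 log units; beyond the scatter) and an at least 6.4-fold higher number from compound 1 to compound 3 (0.80 log units; beyond the scatter), lie beyond the scatter. Compound 4 `COc1ccc2c(=O)c(/C=C/C(=O)Nc3ccccc3C)coc2c1` differs from compound 3 by 2-methylphenyl in place of 4-methoxyphenyl on an amide-type nitrogen. Since the change undoes the methoxy whose arrival gave an at least 11-fold higher number from compound 2 to compound 3 (1.04 log units; beyond the scatter), a large lower number is expected. Compound 4 is estimated at 15000 nM, between 5000 nM and 50000 nM, an expected step of an at least 6.6-fold lower number from compound 3 to compound 4 (0.82 log units; beyond the scatter).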

Compound 4, half-maximal inhibitory concentration: 26900 nM
Beside the measured number, compound 4's estimate is 1.8-fold (0.25 log units) below it, within the range that was stated.
By their numbers in this assay, from the lowest: compounds 2, 1 and 4 (each within the scatter of the next, the first and the last beyond it). At a limit, above all of these: compound 3.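

Compound 3 stands only at a limit of this assay: the limit of > 100000 nM in this assay, at which 1 of the 4 values shown sits. Putting 2-methylphenyl in place of 4-methoxyphenyl on the amide nitrogen brings back a measurable number (an at least 3.7-fold lower number from compound 3 to compound 4 (0.57 log units; beyond the scatter)), so not every substituted phenyl here loses activity as compound 3 does, although the methyl still costs something against the plain phenyl (a 3.0-fold higher number from compound 2 to compound 4 (0.47 log units; beyond the scatter)). The 2-methylphenyl and 3-methylphenyl cannot be told apart (a 1.7-fold higher number from compound 1 to compound 4 (0.24 log units; within the scatter)).

Going by these compounds, whether the loss in compound 3 belongs to the methoxy itself or to where it sits stays open, and a 4-methylphenyl or a 2-methoxyphenyl on the amide nitrogen would separate the two. Also open, on these data alone, is how an amine or a carboxylic acid on that phenyl would read.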